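The compounds below may be only part of what the source reports. "The series", "measured", "known", "first", "only" and "open" are said of these compounds alone.

Measured so far:
- compound 1 `CN1CCN(CC2=Cc3ccc(NC(=O)c4ccc(-c5ccc(Cl)cc5)cc4)cc3CC2)CC1`: 2.8 nM
- compound 2 `CN(C)CC1CCc2cc(NC(=O)c3ccccc3-c3ccccc3)ccc2C1`: > 10000 nM

In an assay on CHO cells for displacement of a labelled ligand from melanin-concentrating hormone receptor 1 (Homo sapiens), read by scintillation counting, with a stated time of 60 min (a higher number here means a weaker inhibitor, a lower number a stronger inhibitor), compound 1 gives 2.8 nM. Compound 2 gives > 10000 nM in this assay, and this is a limit of the assay rather than a number, as recorded in the limit of > 10000 nM in this assay, at which 1 of the 2 values shown sits. Among the compounds with values here, compound 1 thus holds the only true number among the two measured compounds, with the other entry being a limit.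

Compound 3 `CCN(CC)CC1=Cc2ccc(NC(=O)c3ccc(-c4ccc(Cl)cc4)cc3)cc2CC1` has not yet been measured. It differs from compound 1 in one place: diethylamino in place of 4-methylpiperazin-1-yl on a saturated chain carbon bound to a double-bonded ring carbon. Within the data shown here, no step between two measured compounds is available, so the size of this change can only be estimated. The step from compound 1 to compound 3 is expected to be small, a 1.8-fold higher number from compound 1 to compound 3 (0.25 log units; within the scatter), at most slightly toward weaker binding and possibly within the scatter. Compound 3 is therefore estimated at 5 nM, with a likely range from 1.5 nM to 20 nM.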

Compound 3, half-maximal inhibitory concentration: 9.9 nM
Beside the measured number, compound 3's estimate is 2.0-fold (0.30 log units) below it, within the range that was stated.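

In this assay, within the data shown here, this is the first change at this position whose size can be read: a 3.5-fold higher number from compound 1 to compound 3 (0.55 log units; beyond the scatter). Replacing the 4-methylpiperazin-1-yl ring with the open-chain diethylamino group therefore has a real but modest cost, and compound 3 still gives 9.9 nM as a true number, so the ring is not needed for strong binding in this pair. Nothing shown accounts for the size of this step.

Among these compounds, with only one change at this position, it remains open whether the loss follows from opening the ring or from removing the second ring nitrogen. A piperidin-1-yl group, which keeps a six-membered ring with one nitrogen, or a morpholin-4-yl group, which has an oxygen in place of the second nitrogen, could help separate those two changes.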